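Thiazolylmethyl to thiazolylcarbonyl in the sulfonylcarbamate series

The compounds below may be only part of what the source reports. "The series", "measured", "known", "first", "only" and "open" are said of these compounds alone.

Measured so far:
compound 1 `CCCCOC(=O)NS(=O)(=O)c1sc(CC(C)C)cc1-c1ccc(Cc2nccs2)cc1`: 3.2 nM
compound 2 `CCCCOC(=O)NS(=O)(=O)c1sc(CC(C)C)cc1-c1ccc(CN2CCN(C)C2=O)cc1`: 16.5 nM

In an assay on membranes from uterus for displacement of a labelled ligand from Angiotensin type II receptor (Sus scrofa), with a stated time of 1.5 h (on this read-out lower numbers stand for stronger inhibition and higher numbers for weaker inhibition), compound 1 gives 3.2 nM, the lowest of the two numbers in hand; compound 2 gives 16.5 nM. Within the data shown here, the single measured step, a 5.2-fold higher number from compound 1 to compound 2 (0.71 log units; beyond the scatter), exchanges the whole group on the saturated chain carbon while leaving that carbon itself untouched. Compound 3 `CCCCOC(=O)NS(=O)(=O)c1sc(CC(C)C)cc1-c1ccc(C(=O)c2nccs2)cc1` keeps the 1,3-thiazol-2-yl ring of compound 1 and alters only the link to it: (1,3-thiazol-2-yl)carbonyl in place of (1,3-thiazol-2-yl)methyl on an aromatic carbon. Among the measured compounds shown here, no measured pair varies this link, so the step from compound 1 to compound 2 does not bear on it directly; it shows only that alterations on this saturated chain carbon can move the number beyond the scatter. Without a closer precedent, the expected step of a 1.6-fold higher number from compound 1 to compound 3 (0.19 log units; within the scatter) is small, in either direction, and the range is set wide. Compound 3 is expected at 5 nM (range 1.5 nM to 20 nM).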

Compound 3, inhibition constant: 18.6 nM
The estimate for compound 3 lay 3.7-fold (0.57 log units) below the measured number; measured number inside the range.
By their numbers in this assay, from the lowest: compound 1; then compounds 2 and 3 (each within the scatter of the next).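

In this assay the link to the ring carries weight of its own: with the 1,3-thiazol-2-yl ring unchanged, (1,3-thiazol-2-yl)carbonyl in place of (1,3-thiazol-2-yl)methyl gives a 5.8-fold higher number from compound 1 to compound 3 (0.76 log units; beyond the scatter) on this aromatic carbon. The step of a 1.1-fold higher number from compound 2 to compound 3 (0.05 log units; within the scatter) leaves (1,3-thiazol-2-yl)carbonyl and (3-methyl-2-oxoimidazolidin-1-yl)methyl indistinguishable on this read-out, although the two groups differ in both ring and link. Nothing available accounts for the step from the methylene link to the carbonyl link.

Open, on these data alone, is whether a hydroxyl-bearing carbon or an ether oxygen as the link would give a number nearer that of compound 1 or that of compound 3. Also open, as far as these compounds go, is whether the carbonyl link has a similar effect on another ring, such as pyridin-2-yl or oxazol-2-yl.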